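Cyclopropylmethyl thioether analogue of the shared core

The compounds below may be only part of what the source reports. "The series", "measured", "known", "first", "only" and "open" are said of these compounds alone.

Compound 1 `Cc1cc(Nc2cc(-c3ccccc3)[nH]n2)n2nc(SCc3ccc(F)cc3)nc2n1` carries a (4-fluorobenzyl)sulfanyl arm on the shared core. In an ADME assay on GES1 cells (Homo sapiens) for inhibition, read by MTT assay, with a stated time of 72 h (on this read-out higher numbers stand for weaker inhibition and lower numbers for stronger inhibition), compound 1 gives 35500 nM. Compound 2 `Cc1cc(Nc2cc(-c3ccccc3)[nH]n2)n2nc(SCc3ccc([N+](=O)[O-])cc3)nc2n1` gives 43600 nM in this assay, and compound 3 `Cc1cc(Nc2cc(-c3ccccc3)[nH]n2)n2nc(SCc3ccc(Cl)cc3)nc2n1` gives 31800 nM. Among these three numbers compound 1 stands second highest, with compound 3 nearest and compound 2 furthest, and every gap lies within the scatter. The measured steps read: a 1.2-fold higher number from compound 1 to compound 2 (0.09 log units; within the scatter); a 1.1-fold lower number from compound 1 to compound 3 (0.05 log units; within the scatter); a 1.4-fold lower number from compound 2 to compound 3 (0.14 log units; within the scatter). So far, exchanging the substituent on the six-membered aromatic ring of the benzyl arm has not moved the number beyond the scatter in this assay.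

Compound 4 `Cc1cc(Nc2cc(-c3ccccc3)[nH]n2)n2nc(SCC3CC3)nc2n1` is not yet measured. It differs from compound 1 in one place: cyclopropyl in place of 4-fluorophenyl on a saturated chain carbon bound to a sulfur. Among the compounds with values here, none of the measured steps touches this change directly; each of them swaps one substituent on the six-membered aromatic ring for another, whereas here that ring leaves entirely and a three-membered non-aromatic ring enters. Within the data shown here, the only guidance is that all measured steps on this arm stayed within the scatter in this assay. The expectation for compound 4 is therefore a step of a 1.1-fold higher number from compound 1 to compound 4 (0.03 log units; within the scatter), with no direction beyond the scatter. Compound 4 is estimated at 38000 nM in this assay, within the range 15000 nM to 95000 nM.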

Compound 4, half-maximal inhibitory concentration: > 50000 nM
Compound 4: a limit, no number; the forecaster's own chance of this, stated with the estimate: 20%; middle value at least 1.3-fold (0.11 log units) from the limit.
By their numbers in this assay, from the lowest: compounds 3, 1 and 2 (each within the scatter of the next). At a limit, above all of these: compound 4.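

In this assay, compound 4 gives a limit and not a number: the limit of > 50000 nM in this assay, at which 1 of the 4 values shown sits. With the six-membered aromatic ring gone from the arm, the steps can be read only as floors: an at least 1.4-fold higher number from compound 1 to compound 4 (0.14 log units; that floor lies within the scatter), an at least 1.5-fold higher number from compound 3 to compound 4 (0.19 log units; that floor lies within the scatter) and an at least 1.1-fold higher number from compound 2 to compound 4 (0.05 log units; that floor lies within the scatter). Within the data shown here, the earlier exchanges on that ring all gave numbers within the scatter of each other, whereas cyclopropyl in place of 4-fluorophenyl puts compound 4 at a limit above all three, so this position is the first on the arm where a step may exceed the scatter, although each floor itself lies within it and the size of the step stays unknown.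

The compounds shown leave open how far compound 4 lies from the benzyl compounds, and whether the outcome follows the departure of the aromatic ring or the entry of the cyclopropyl ring. A plain longer chain on the sulfur, or a benzyl arm carrying an amine or a carboxylic acid on its ring, would test whether the number on this arm moves beyond the scatter at all.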